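This account rests on a few compounds, and the source may have more. Where it says the series, first, only, none or still open, it means among the compounds named here.

Compound 1 `COc1cc(-c2nn(-c3cccc(NC(=O)Nc4ccc(Cl)c(Cl)c4)c3)cc2-c2ccncc2)ccc1Cl`: 2440 nM
Compound 2 `O=C(Nc1cccc(-n2cc(-c3ccncc3)c(-c3ccc(Cl)c(O)c3)n2)c1)Nc1ccc(Cl)c(Cl)c1`: 6400 nM
Compound 3 `O=C(Nc1cccc(-n2cc(-c3ccncc3)c(-c3ccc(Cl)c(O)c3)n2)c1)Nc1cc(C(F)(F)F)cc(C(F)(F)F)c1`: 2490 nM

These three were measured in a functional assay on RXF 393 cells (Homo sapiens) for inhibition, read by sulforhodamine B assay, with a stated time of 48 h; a lower number here means a stronger inhibitor of growth, a higher number a weaker inhibitor of growth. Compound 1 has the lowest of the three numbers, with compound 3 standing within the scatter of it and compound 2 further away. Among the measured compounds shown here, the one single-point step available, a 2.6-fold higher number from compound 1 to compound 2 (0.42 log units; beyond the scatter), concerns the methyl on the oxygen of the shared core and says nothing about the urea end of the molecule.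

Compound 4 `COc1cc(-c2nn(-c3cccc(NC(=O)Nc4ccc(Cl)c(C(F)(F)F)c4)c3)cc2-c2ccncc2)ccc1Cl` differs from compound 1 at that urea end: trifluoromethyl in place of chloro on an aromatic carbon. For the measured compounds named here, no measured step covers exactly this change. Going by the values given here, the only hint comes from compounds 2 and 3, which differ on the same urea aryl ring: compound 2 shows 6400 nM and compound 3 shows 2490 nM; there, bringing trifluoromethyl groups onto that ring went with a lower number. On that slim basis the expected step of a 1.4-fold lower number from compound 1 to compound 4 (0.13 log units; within the scatter) is small and toward a lower number, or none beyond the scatter. Compound 4 is therefore estimated at 1800 nM, within a range from 700 nM to 4500 nM.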

Compound 4, concentration for total growth inhibition: 6290 nM
Compound 4: middle estimate off by 3.5-fold (0.54 log units), on the low side; the whole stated range lies below it.
By their numbers in this assay, from the lowest: compounds 1 and 3 (each within the scatter of the next); then compounds 4 and 2 (each within the scatter of the next).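

In this assay, among the compounds shown here, the swap of chloro for trifluoromethyl, on an aromatic carbon ortho to a chloro group, gives a 2.6-fold higher number from compound 1 to compound 4 (0.41 log units; beyond the scatter) and is the only direct reading of this position with the rest of the molecule held constant. The position is therefore not indifferent to what sits there: going from 3,4-dichlorophenyl to 4-chloro-3-(trifluoromethyl)phenyl, with one heavy atom leaving and four entering, goes with weaker growth inhibition in this one pair. Nothing shown here explains why the number rises.

Going by these compounds, whether the same swap would act alike on the core of compound 2, with hydrogen in place of the methyl on the oxygen, stays open. So does how a methyl, a bromo or a nitrile at this place would read, which would show whether the rise follows the size of the group or belongs to trifluoromethyl alone.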